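The source may hold more compounds than are shown below. What is called first, only, known or untested is meant among the compounds shown, and "the series" means these compounds.

Compound 1 `Cc1cccc(-n2nncc2CN2C(=O)C3(C(C#N)=C(N)Oc4c3c3nc5ccccc5nc3c3ccccc43)c3ccccc32)c1`: 39600 nM
Compound 2 `N#CC1=C(N)Oc2c(c3nc4ccccc4nc3c3ccccc23)C12C(=O)N(Cc1cnnn1-c1ccc(F)cc1)c1ccccc12`: > 50000 nM

Of the compounds shown here, two sharing one large core have been tested. In a functional assay on A549 cells (Homo sapiens) for antiproliferative activity, read by MTT assay, with a stated time of 48 h (on this read-out lower numbers stand for stronger inhibition and higher numbers for weaker inhibition), compound 1 gives 39600 nM. Compound 2 reaches only > 50000 nM, which is a limit of the assay and not a measured number. This is where compound 2 stands: at the edge of what this assay can report, with a weaker result than compound 1, though how much weaker is not known (the limit of > 50000 nM in this assay, at which 1 of the 2 values shown sits). Within the data shown here, the only measured step, an at least 1.2-fold higher number from compound 1 to compound 2 (0.10 log units; that floor lies within the scatter), is a floor that lies within the scatter of repeated measurements.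

Compound 3 `N#CC1=C(N)Oc2c(c3nc4ccccc4nc3c3ccccc23)C12C(=O)N(Cc1cnnn1-c1ccc(Br)cc1)c1ccccc12` differs from compound 2 by bromo in place of fluoro on an aromatic carbon. Among the measured compounds shown here, no measured step swaps one halogen for another, so the only guide is that the measured step on the same phenyl ring attached to the aromatic nitrogen was small. Compound 3 is therefore expected to sit close to compound 2, and a step that the limit leaves unreadable from compound 2 to compound 3 is the expected step, not beyond the scatter. The estimate for compound 3 is 55000 nM, with a range from 20000 nM to 150000 nM, and a real chance that this assay again reports only a limit.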

Compound 3, half-maximal inhibitory concentration: 44300 nM
Estimate against measurement, compound 3: 1.2-fold (0.09 log units) above; the measured number falls inside the stated range.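

Compound 3 gives this position a halogen-bearing ring with a measured number, and the comparison with the methyl-bearing ring reads a 1.1-fold higher number from compound 1 to compound 3 (0.05 log units; within the scatter), so in this assay 4-bromophenyl and 3-methylphenyl cannot be told apart. From the compounds shown here alone, the swap of the halogen itself reads an at least 1.1-fold lower number from compound 2 to compound 3 (0.05 log units; that floor lies within the scatter); this is only a floor, so the true size of the change from fluoro to bromo stays unknown, and nothing printed places it beyond the scatter. Compound 2 gives > 50000 nM, which is a limit of the assay and not a number, and it remains the one compound here that cannot be placed exactly: the limit of > 50000 nM in this assay, at which 1 of the 3 values shown sits.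

The compounds shown leave open whether an amine or a carboxylic acid on this phenyl ring, or a longer chain in place of the ring, would give a clearly lower number. They also leave open whether a change to the shared core, and not to this outer ring, would move the result beyond the scatter.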